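The source may report more compounds than this note shows. Statements on the series, on what has been measured and on what is new or still open speak of the compounds shown alone.

Among the measured compounds shown here, in a functional assay on MDA-MB-231 cells (Homo sapiens) for antiproliferative activity, read by sulforhodamine B assay (on this read-out higher numbers stand for weaker inhibition of growth and lower numbers for stronger inhibition of growth), compound 3 `O=C(Nc1cccc([N+](=O)[O-])c1)Nc1nc2ccc(F)cc2s1` gives 0.89 ug/mL, the only actual number among the three compounds measured. Compound 1 `COc1ccccc1NC(=O)Nc1nc2ccc(F)cc2s1` gives just a limit, > 10 ug/mL. Compound 2 `O=C(Nc1ccccc1)Nc1nc2ccc(F)cc2s1` likewise gives just a limit, > 10 ug/mL. The step that the two limits leave unreadable from compound 1 to compound 2 cannot be read because of the limit of > 10 ug/mL in this assay, at which 2 of the 3 values shown sit, whereas an at least 11-fold lower number from compound 2 to compound 3 (1.05 log units; beyond the scatter) is large. Compound 4 `Cc1ccc2nc(NC(=O)Nc3cccc([N+](=O)[O-])c3)sc2c1` differs from compound 3 by methyl in place of fluoro on an aromatic carbon. For the measured compounds named here, neither measured step touches the fused ring where this change sits; no measured step bears on it directly, and the expectation is a change within the scatter, a 1.1-fold higher number from compound 3 to compound 4 (0.05 log units; within the scatter). Compound 4 is accordingly estimated at 1 ug/mL in this assay, with a range from 0.4 ug/mL to 3 ug/mL.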

Compound 4, concentration for 50% growth inhibition: > 10 ug/mL
Compound 4: no number, only a limit; the forecaster's own chance of this, stated with the estimate: 10%; at least 10-fold (1.00 log units) between middle value and limit.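

In this assay, among the compounds shown here, methyl in place of fluoro on the fused ring gives an at least 11-fold higher number from compound 3 to compound 4 (1.05 log units; beyond the scatter), so this position, which no earlier step touched, responds strongly to the change. The nitro group shared by compound 3 and compound 4 therefore does not bring a measurable number on its own, only together with fluoro here. The true size of the step stays unknown because compound 4 gives only a limit: the limit of > 10 ug/mL in this assay, at which 3 of the 4 values shown sit.

Still open, on these data alone, is whether fluoro itself matters or methyl alone is the problem. Hydrogen or chloro on this aromatic carbon would help separate the two.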